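Turning the ring stereocentres of compound 2

This account rests on a few compounds, and the source may have more. Where it says the series, first, only, none or still open, it means among the compounds named here.

Compound 2 `S=C=N[C@H]1C[C@@H](OCc2ccc(-c3ccccc3)cc2)C1` sits in the middle of the three measured compounds in an assay on isolated protein for inhibition of N-acylethanolamine-hydrolyzing acid amidase (Homo sapiens), read by fluorescence, with a stated time of 90 min; on this read-out higher numbers stand for weaker inhibition and lower numbers for stronger inhibition: it gives 93 nM, while compound 1 `Cc1ccc(-c2ccc(CO[C@H]3C[C@@H](N=C=S)C3)cc2)cc1` gives 26 nM and compound 3 `COc1ccc(-c2ccc(CO[C@H]3CC[C@@H](N=C=S)CC3)cc2)cc1F` gives 386 nM. Within the data shown here, the single measured step that joins two of these, a 3.6-fold higher number from compound 1 to compound 2 (0.55 log units; beyond the scatter), is a change of a substituent on an aromatic carbon and says nothing about the saturated ring.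

Compound 4 `S=C=N[C@H]1C[C@H](OCc2ccc(-c3ccccc3)cc2)C1` differs from compound 2 only in configuration: the two compounds have the same atoms and bonds; at least one stereo element is drawn with a configuration in one of them and without one in the other: 2 of 3 stereo elements differ; a stereocentre at a saturated ring carbon is drawn s in compound 2 and r in compound 4; a stereocentre at a saturated ring carbon is drawn s in compound 2 and r in compound 4. Among the measured compounds shown here, no measured pair shows the effect of inverting a stereocentre at a saturated ring carbon, so none of the three measured steps bears on this change directly. What the measured numbers do show is that the entire series stays within a few steps of each other in this assay, and that compound 3, with a different saturated ring, reaches 386 nM.

Given the absence of a precedent, a change in the relative arrangement of the two substituents on the saturated ring is expected to shift the number beyond the scatter, most plausibly towards weaker inhibition, but with a wide range on either side. Compound 4 is therefore estimated at 250 nM (range 50 nM to 2000 nM), which would mean an expected step of a 2.7-fold higher number from compound 2 to compound 4 (0.43 log units; beyond the scatter).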

Compound 4, half-maximal inhibitory concentration: 4300 nM
Compound 4: the middle estimate sits 17-fold (1.24 log units) below what was measured; the whole stated range lies below it.
By their numbers in this assay, from the lowest: compound 1; then compound 2; then compound 3; then compound 4.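

In this assay, among these compounds, the saturated ring proves far more sensitive to the arrangement of its two substituents than the earlier compounds could show. Among the compounds shown here, with atoms and bonds unchanged, the step is a 46-fold higher number from compound 2 to compound 4 (1.66 log units; beyond the scatter) and it clearly outweighs the only earlier step, a 3.6-fold higher number from compound 1 to compound 2 (0.55 log units; beyond the scatter) on a substituent of an aromatic carbon. This places the larger effect seen so far at the saturated ring carbons rather than on the aromatic end of the molecule, although the size of the step has to be read with one reservation about how the two compounds are drawn: the fact that one of compounds 2 and 4 is drawn with a defined configuration and the other without, at the place where they differ.

As far as these compounds go, whether the arrangement matters as much with the methyl group of compound 1, or on the different saturated ring of compound 3, stays open. Also open, from the compounds shown here alone, is how a group other than the isothiocyanate, such as a carboxylic acid or a primary amine, would behave on the ring of compound 2, and whether the preference for the arrangement in compound 2 would survive that replacement.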